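The source may hold more compounds than are shown below. What is called first, only, known or untested is meant among the compounds shown, and "the series" means these compounds.

In an ADME assay on NIH3T3 cells (Mus musculus) for cytotoxicity (a lower number here means that less compound is tolerated, a higher number that more compound is tolerated), compound 1 `CCCN(CC#Cc1cc2ncnc(Nc3ccc(OCc4cccc(F)c4)c(Cl)c3)c2s1)CCC` gives > 50 uM as a limit and not a number. Compound 2 `Fc1cccc(COc2ccc(Nc3ncnc4cc(C#CCN5CCNCC5)sc34)cc2Cl)c1` gives > 50 uM as a limit too. Among the compounds with values here, compound 3 `CN1CCN(CC#Cc2cc3c(Nc4ccc(OCc5cccc(F)c5)c(Cl)c4)ncnc3s2)CC1` gives 6.7 uM as the only true number in the set.

Compound 4 `COCC#Cc1cc2c(Nc3ccc(OCc4cccc(F)c4)c(Cl)c3)ncnc2s1` follows from compound 3 by one change: methoxy in place of 4-methylpiperazin-1-yl on a saturated chain carbon bound to a triple-bonded carbon with methoxy in place of 4-methylpiperazin-1-yl on a saturated chain carbon bound to a triple-bonded carbon.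

Within the data shown here, the only measured step at this place is a step that the two limits leave unreadable from compound 1 to compound 2 and it gives no size to carry over. For compound 1 and compound 2 the evidence stops at the limit of > 50 uM in this assay, at which 2 of the 3 values shown sit, and holds no methoxy group. Any expectation is therefore loose, and it rests on compound 3 at 6.7 uM having room to move upward in this assay towards where the other two stand. The expected move is a 2.2-fold higher number from compound 3 to compound 4 (0.35 log units; beyond the scatter) and it is held with little confidence. Compound 4 is estimated at 15 uM with an expected range from 5 uM to 50 uM and a reading that is only a limit stays possible.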

Compound 4, half-maximal toxic concentration: 1.7 uM
Compound 4: the middle estimate sits 8.8-fold (0.95 log units) above what was measured; the whole stated range lies above it.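

In this assay the change to methoxy from 4-methylpiperazin-1-yl on a saturated chain carbon bound to a triple-bonded carbon gives the first readable size at this place (a 3.9-fold lower number from compound 3 to compound 4 (0.60 log units; beyond the scatter)). The direction is downward: on the core of compound 3, less compound is tolerated once the ring leaves and methoxy enters, so the read-out at this place can move down as well as up. Compound 1 and compound 2 could not show this, as the step between them cannot be read and both readings are limits: the limit of > 50 uM in this assay, at which 2 of the 4 values shown sit.

As far as these compounds go, with a single readable step, it stays open whether the lower number goes with methoxy itself or with the loss of the 4-methylpiperazin-1-yl ring. A morpholine ring or a free hydroxyl on the same saturated chain carbon would help separate the two.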